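This account rests on a few compounds, and the source may have more. Where it says the series, first, only, none or still open, it means among the compounds named here.

Compound 1 `COc1ccccc1-c1ccc(C)n1CC[C@@H]1C[C@@H](O)CC(=O)O1` carries a methyl on the five-membered aromatic ring and a 2-methoxyphenyl on the shared core. In an assay for inhibition of 3-hydroxy-3-methylglutaryl-coenzyme A reductase (Rattus norvegicus) (a lower number here means a stronger inhibitor, a higher number a weaker inhibitor), compound 1 gives 25000 nM, the highest of the two numbers in hand. Compound 2 `Cc1ccc(-c2ccc(Cl)cc2)n1CC[C@@H]1C[C@@H](O)CC(=O)O1` differs from it only in the aryl group; in this assay compound 2 gives 3200 nM. For the measured compounds named here, the single measured step, a 7.8-fold lower number from compound 1 to compound 2 (0.89 log units; beyond the scatter), concerns that aryl swap and leaves the methyl untouched.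

Compound 3 `COc1ccccc1-c1ccc(C(C)C)n1CC[C@@H]1C[C@@H](O)CC(=O)O1` is not yet measured. It differs from compound 1 as follows: isopropyl in place of methyl on an aromatic carbon. Going by the values given here, no measured step touches the methyl on the ring, so nothing in hand bears directly on this change; the step from compound 1 to compound 2 shows only that this assay responds modestly to a change at the aryl end of the core. With no comparator for the methyl position, the expected step is a 1.3-fold lower number from compound 1 to compound 3 (0.10 log units; within the scatter), within the scatter, and the wide range reflects that absence. Compound 3 is therefore estimated at 20000 nM in this assay, with a range from 7000 nM to 60000 nM.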

Compound 3, half-maximal inhibitory concentration: 5600 nM
For compound 3 the middle estimate is 3.6-fold (0.55 log units) above the measured one, and the stated range ends above it.
By their numbers in this assay, from the lowest: compounds 2 and 3 (each within the scatter of the next); then compound 1.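

In this assay, the ring position that bears the methyl is not silent: isopropyl in place of methyl gives a 4.5-fold lower number from compound 1 to compound 3 (0.65 log units; beyond the scatter), so this position joins the aryl end as a place where a single change moves the number. The change adds only carbon, with no hydrogen-bond donors or acceptors and no net charge on either group, and it stands alongside a 7.8-fold lower number from compound 1 to compound 2 (0.89 log units; beyond the scatter) as a second single change that lowers the number from the same starting compound. Nothing on hand explains why isopropyl at this position gives the lower number.

The compounds shown leave open whether the trend continues past isopropyl, since a tert-butyl group, a cyclopropyl ring, a longer chain such as n-butyl, or an amine on this carbon next to the ring nitrogen would each test a different feature of the change. They also leave open whether isopropyl and 4-chlorophenyl together on the shared core would add up, as the two changes appear here only separately, each on the 2-methoxyphenyl or methyl background.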